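The compounds below may be only part of what the source reports. "The series", "measured", "known", "first", "only" and "open" are said of these compounds alone.

Compound 1 `N#Cc1ccc(C2OCC(C/C=C\CCC(=O)O)C(c3cccnc3)O2)cc1`: in an assay for inhibition of Thromboxane-A synthase (Homo sapiens), using microsomes (a higher number here means a weaker inhibitor, a lower number a stronger inhibitor), compound 1 gives 24 nM.
Compound 2 `N#Cc1ccccc1C1OCC(C/C=C\CCC(=O)O)C(c2cccnc2)O1`: compound 2 gives 54 nM.
Compound 3 `Cc1ccc(OC(C)(C)C2OCC(C/C=C\CCC(=O)O)C(c3cccnc3)O2)cc1`: compound 3 gives 360 nM.

Among these three, compound 3 has the highest number and is therefore the weakest inhibitor of the set, with compound 2 nearer to it and compound 1 furthest away. Compound 4 `COc1ccc(OC(C)(C)C2OCC(C/C=C\CCC(=O)O)C(c3cccnc3)O2)c([N+](=O)[O-])c1` is built from compound 3 by one change: 4-methoxy-2-nitrophenyl in place of 4-methylphenyl on an oxygen on a saturated carbon. Going by the values given here, the only measured step between neighbours is a 2.3-fold higher number from compound 1 to compound 2 (0.35 log units; beyond the scatter), and that step concerns the aryl group on the saturated ring carbon, not the group on the oxygen, so it bears only loosely on the change at hand. Among the compounds with values here, there is no measured pair that shows what swapping the aromatic group on this oxygen does. The expectation is therefore a step of a 1.2-fold lower number from compound 3 to compound 4 (0.08 log units; within the scatter), small in either direction and with a wide range. For compound 4 in this assay the estimate is 300 nM, expected to fall between 70 nM and 1300 nM.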

Compound 4, half-maximal inhibitory concentration: 37 nM
The estimate for compound 4 lay 8.1-fold (0.91 log units) above the measured number; measured number outside the range, below it.
By their numbers in this assay, from the lowest: compounds 1, 4 and 2 (each within the scatter of the next, the first and the last beyond it); then compound 3.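

Replacing 4-methylphenyl with 4-methoxy-2-nitrophenyl on an oxygen on a saturated carbon gives a 9.7-fold lower number from compound 3 to compound 4 (0.99 log units; beyond the scatter) in this assay and so shows that the aromatic group at this position can strongly change the number. Going by these compounds alone, the earlier measured step concerned only the aryl group on a saturated ring carbon, so this is the first measured sign that the group on the oxygen matters too. No available measurement explains the size of this step.

The methoxy and nitro groups enter together, so the compounds shown cannot say whether one of them accounts for the step or both are needed. They also leave open how an unsubstituted phenyl ring, or an aromatic ring carrying an amine or a carboxylic acid, would behave on this oxygen.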